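The source may hold more compounds than are shown below. What is called first, only, known or untested is meant among the compounds shown, and "the series" means these compounds.

Measured so far:
- Compound 1, `COc1cc(/C=C/C(=O)c2cccc(-n3cc(-c4ccc(Cl)cc4)[nH]c3=O)c2)cc(OC)c1OC`: 4100 nM
- Compound 2, `COc1ccc(-c2cn(-c3cccc(C(=O)/C=C/c4ccc(O)c(OC)c4)c3)c(=O)[nH]2)cc1`: 3480 nM

Both compounds were tested in a functional assay on NCI-H522 cells (Homo sapiens) for inhibition; on this read-out lower numbers stand for stronger inhibition of growth and higher numbers for weaker inhibition of growth. In this assay compound 1 gives 4100 nM, and compound 2 gives 3480 nM. Compound 2 has the lowest number of the two, but the gap to compound 1 lies within the usual scatter of repeated measurements, so the two results cannot be told apart.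

The next compound, compound 3, has the structure `COc1ccc(-c2cn(-c3cccc(C(=O)/C=C/c4cc(OC)c(OC)c(OC)c4)c3)c(=O)[nH]2)cc1`. It is made from compound 2 by one change: 3,4,5-trimethoxyphenyl in place of 4-hydroxy-3-methoxyphenyl on a double-bonded chain carbon bound to a double-bonded chain carbon. Within the data shown here, no pair of measured compounds differs in exactly this one place, so no measured step can be read off for it. Compound 1 carries the same 3,4,5-trimethoxyphenyl group on its chain and gives a number close to that of compound 2, which suggests no step beyond the scatter here. The expected step from compound 2 to compound 3 is therefore a 1.1-fold higher number from compound 2 to compound 3 (0.04 log units; within the scatter). Compound 3 is accordingly expected to give about 3800 nM in this assay, with a likely range from 1500 nM to 9000 nM.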

Compound 3, concentration for 50% growth inhibition: 1850 nM
The estimate for compound 3 lay 2.1-fold (0.31 log units) above the measured number; the range from low to high includes it.
By their numbers in this assay, from the lowest: compounds 3, 2 and 1 (each within the scatter of the next, the first and the last beyond it).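

In this assay, placing 3,4,5-trimethoxyphenyl in place of 4-hydroxy-3-methoxyphenyl on the chain gives a 1.9-fold lower number from compound 2 to compound 3 (0.27 log units; within the scatter) and so, at this place, a group with one hydrogen-bond donor and a group with none cannot be told apart. With 3,4,5-trimethoxyphenyl held fixed on the chain, the comparison moves to another place, where methoxy in place of chloro on an aromatic carbon gives a 2.2-fold lower number from compound 1 to compound 3 (0.35 log units; beyond the scatter) and forms a modest step, the only one here that clears the scatter. Nothing available here bears on what lies behind either step.

Going by these compounds, it remains open whether a fluoro or a dimethylamino group on that aromatic carbon would fit the same trend as methoxy and chloro. A carboxylic acid on the chain's aromatic ring is also untested among the compounds shown here, so how far that ring tolerates change is unknown.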